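The source may report more compounds than this note shows. Statements on the series, on what has been measured and on what is new or still open speak of the compounds shown alone.

Values in a functional assay on HOS cells (Homo sapiens) for inhibition, with a stated time of 72 h; on this read-out lower numbers stand for stronger inhibition and higher numbers for weaker inhibition:
- compound 1 `NC1CCC(Nc2nc(NCc3ccc(-c4ccccc4)cc3)c3ncn(C4CCCC4)c3n2)CC1`: 290 nM
- compound 2 `NC1CCC(Nc2nc(NCc3ccc(-c4ccco4)cc3)c3ncn(C4CCCC4)c3n2)CC1`: 102 nM
- compound 3 `NC1CCC(Nc2nc(NCc3ccc(-n4cccn4)cc3)c3ncn(C4CCCC4)c3n2)CC1`: 103 nM

Two of the three numbers sit together at the low end, with a 1.0-fold higher number from compound 2 to compound 3 (0.00 log units; within the scatter). Compound 3 belongs to that pair, and the third number is set apart, with a 2.8-fold lower number from compound 1 to compound 3 (0.45 log units; beyond the scatter).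

Compound 4 `NC1CCC(Nc2nc(NCc3ccc(-c4ccccc4)nc3)c3ncn(C4CCCC4)c3n2)CC1` carries 6-phenylpyridin-3-yl in place of 4-(1H-pyrazol-1-yl)phenyl on a saturated chain carbon bound to a nitrogen on an aromatic ring.

Within the data shown here, no measured step covers this change directly. The nearest guide is a 2.8-fold lower number from compound 1 to compound 3 (0.45 log units; beyond the scatter), where 1H-pyrazol-1-yl replaced phenyl. A phenyl returns in compound 4, now as part of 6-phenylpyridin-3-yl, so some or all of that modest step may be reversed. The step of a 2.8-fold lower number from compound 1 to compound 2 (0.45 log units; beyond the scatter) is of the same size and shows that the number for compound 1 is the one that stands apart so far. Among the measured compounds shown here, no measured compound shows the effect of a pyridine in this group, which leaves the estimate open on that side.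

A modest rise in this assay is therefore expected, and it may not clear the scatter. The expected step is a 1.7-fold higher number from compound 3 to compound 4 (0.22 log units; within the scatter). For compound 4 the estimated value is 170 nM, with an expected range of 65 nM to 440 nM.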

Compound 4, half-maximal inhibitory concentration: 206 nM
The estimate for compound 4 lay 1.2-fold (0.08 log units) below the measured number, and the stated range covers the measured number.
By their numbers in this assay, from the lowest: compounds 2, 3, 4 and 1 (each within the scatter of the next, the first and the last beyond it).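

In this assay, among these compounds, the 6-phenylpyridin-3-yl group brings a pyridine ring to this position for the first time, and the swap from 4-phenylphenyl gives a 1.4-fold lower number from compound 1 to compound 4 (0.15 log units; within the scatter), so this single ring change cannot be read as a real difference. Compound 4 also stands within the scatter of the pyrazole analogue, with a 2.0-fold higher number from compound 3 to compound 4 (0.30 log units; within the scatter), but only just beyond that of the furan analogue, with a 2.0-fold higher number from compound 2 to compound 4 (0.31 log units; beyond the scatter), so the earlier clear separation of compound 1 from compound 2 and compound 3 now has a compound lying in the gap, and the position reads as a shallow range of values rather than two distinct levels. Nothing given here accounts for these steps.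

Still open, going by these compounds, is whether the ring nitrogen of the pyridine matters when the phenyl is replaced, as a 6-(furan-2-yl)pyridin-3-yl or 6-(1H-pyrazol-1-yl)pyridin-3-yl group would show. Also open, on these data alone, is how a carboxylic acid or an amine in place of the phenyl of 6-phenylpyridin-3-yl would read in this assay.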